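A Chloro Step From Compound 3 to Compound 4

This account rests on a few compounds, and the source may have more. Where it says the series, first, only, none or still open, it means among the compounds named here.

Growth inhibition by this small series was measured in a functional assay on NCI-H460 cells (Homo sapiens) for inhibition, read by MTT assay, with a stated time of 24 h, tested at 0.1 ug/mL; on this read-out lower numbers stand for less inhibition of growth and higher numbers for more inhibition of growth at the one concentration tested. Compound 1 `O=C(O)CCCCC(CCSC(=O)c1ccccc1)SC(=O)c1ccccc1` gives "not active" (no number reported), with no number reported. Compound 2 `O=C(CCCCC(S)CCS)Nc1ccc(OC(F)(F)F)cc1` gives 17.3%. Compound 3 `O=C(CCCCC(CCSC(=O)c1ccccc1)SC(=O)c1ccccc1)Nc1ccccc1` gives 0.6%, the lower of the two numbers available, and the gap to compound 2 lies beyond the usual scatter.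

Compound 4 `O=C(CCCCC(CCSC(=O)c1ccccc1)SC(=O)c1ccccc1)Nc1ccccc1Cl` has not yet been measured. It departs from compound 3 at one place chloro in place of hydrogen on an aromatic carbon, ortho to a large group, so that phenylcarbamoyl becomes (2-chlorophenyl)carbamoyl. Among the measured compounds shown here, no measured pair shows this kind of change, so the data give no direct guide to its size. Compound 3 already reads 0.6%, so any movement is expected to be small and upward, and it may not exceed the scatter. The expected step is a number 4.4 percentage points higher from compound 3 to compound 4 (within the scatter). Compound 4 is estimated at 5%, with an expected range from 0% to 16%.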

Compound 4, percent growth inhibition at one concentration: 15.1%
The estimate for compound 4 lay 10.1 percentage points below the measured number; the measured number falls inside the stated range.
By their numbers in this assay, from the lowest: compound 3; then compounds 4 and 2 (each within the scatter of the next).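

In this assay, the first step read at this position, chloro in place of hydrogen on an aromatic carbon, ortho to a large group, gives a number 14.5 percentage points higher from compound 3 to compound 4 (beyond the scatter) and so lies beyond the usual scatter. The earlier compounds shown here offered no pair differing in one place, whereas this pair shows that the phenylcarbamoyl end of the series responds to a single added heavy atom, the change from phenyl to 2-chlorophenyl, with the rest of the structure unchanged. Nothing measured here gives a reason for this step.

The compounds shown leave open whether a fluoro, a methyl or a methoxy on this same carbon would give a step of like size, or whether chloro elsewhere on the ring would. On these data alone, it also remains open whether the chloro step would carry over to compounds with free thiol groups, such as compound 2.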